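The source may report more compounds than this note shows. Statements on the series, on what has been measured and on what is new or still open speak of the compounds shown alone.

Measured so far:
Compound 1 `CC(C)N/C(=N\c1nccn1C(C)C)Nc1ccc(Cl)c(Cl)c1` — 0.0983 h
Compound 2 `CC(C)n1ccnc1/N=C(\N)Nc1ccc(Cl)c(Cl)c1` — 0.462 h
Compound 3 `CC(C)N1CCN=C1/N=C(\N)Nc1ccc(Cl)c(Cl)c1` — its value is a limit of the assay, > 1 h

All three were tested in an in vitro ADME assay on microsomes from liver (Mus musculus) for metabolic stability, read by LC-MS, tested at 1 uM; on this read-out higher numbers stand for a longer-lived compound and lower numbers for a shorter-lived compound. Compound 3 sits at the limit of > 1 h in this assay, at which 1 of the 3 values shown sits, so for compound 3 only a range is known. The difference between the core of compound 2 and the core of compound 3 is not broken down here. Compound 2 and compound 1 differ by isopropyl in place of hydrogen on an amine nitrogen, and that change gave a 4.7-fold lower number from compound 2 to compound 1 (0.67 log units; beyond the scatter).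

Compound 4 `CC(C)N/C(=N\C1=NCCN1C(C)C)Nc1ccc(Cl)c(Cl)c1` is not yet measured. Going by the values given here, it differs from compound 3 by isopropyl in place of hydrogen on an amine nitrogen, the same change as the one from compound 2 to compound 1. Resting on that earlier step, compound 4 is expected to show a shorter half-life than compound 3, with an estimated step of an at least 2.0-fold lower number from compound 3 to compound 4 (0.30 log units; that floor lies within the scatter). Compound 4 is thus estimated at 0.5 h, with a range from 0.2 h to 1.5 h.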

Compound 4, half-life: 0.227 h
Compound 4: the middle estimate sits 2.2-fold (0.34 log units) above what was measured, and the stated range covers the measured number.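

In this assay, isopropyl in place of hydrogen on an amine nitrogen gave an at least 4.4-fold lower number from compound 3 to compound 4 (0.64 log units; beyond the scatter) on the core of compound 3. The change therefore went the same way on both cores, which shows that its direction carried over within these two pairs: the same change on two cores in this assay, a 4.7-fold lower number (0.67 log units; beyond the scatter) from compound 2 to compound 1 and an at least 4.4-fold lower number (0.64 log units; beyond the scatter) from compound 3 to compound 4; the limit leaves it open whether they differ
Compound 3 gives > 1 h, a limit of the assay, so how closely the size of the change carried over is not shown: the limit of > 1 h in this assay, at which 1 of the 4 values shown sits.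

The compounds shown leave open how methyl or a longer chain would behave on the same amine nitrogen. They also leave open whether the isopropyl change would go the same way on any core beyond these two.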